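The source may hold more compounds than are shown below. What is called first, only, known or untested is meant among the compounds shown, and "the series" means these compounds.

For the measured compounds named here, compound 1 `Clc1ccc(-c2cc(-c3ccoc3)cc(-c3cccs3)n2)cc1` in a functional assay on HeLa cells (Homo sapiens) for cytotoxicity, in the presence of a further agent that is not named here (a lower number here means a stronger inhibitor, a higher number a weaker inhibitor), gives 5530 nM, the higher of the two numbers measured so far. Compound 2 `Clc1ccc(-c2cc(-c3ccoc3)cc(-c3ccsc3)n2)cc1` in this assay gives 4140 nM, and the step of a 1.3-fold lower number from compound 1 to compound 2 (0.13 log units; within the scatter) shifts the attachment point of the thiophene ring and stays within the scatter. Compound 3 `Clc1ccc(-c2cc(-c3ccco3)cc(-c3cccs3)n2)cc1` differs from compound 1 by furan-2-yl in place of furan-3-yl on an aromatic carbon, the same kind of shift on the furan ring. Since the comparable step a 1.3-fold lower number from compound 1 to compound 2 (0.13 log units; within the scatter) stayed within the scatter, the expected step of a 1.1-fold lower number from compound 1 to compound 3 (0.04 log units; within the scatter) is none beyond the scatter. Compound 3 is therefore estimated at 5000 nM, with a range from 2000 nM to 12000 nM.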

Compound 3, half-maximal inhibitory concentration: 32700 nM
Compound 3: middle estimate off by 6.5-fold (0.82 log units), on the low side, outside the stated range (above it).
By their numbers in this assay, from the lowest: compounds 2 and 1 (each within the scatter of the next); then compound 3.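

Moving the attachment point of the furan on the carbon opposite the ring nitrogen gives a 5.9-fold higher number from compound 1 to compound 3 (0.77 log units; beyond the scatter) in this assay even though furan-3-yl and furan-2-yl have the same atoms and counts. The matching thiophene shift, a 1.3-fold lower number from compound 1 to compound 2 (0.13 log units; within the scatter), stayed within the scatter, so at this position the attachment point matters for the furan, and the thiophene result did not carry over. Nothing available explains this difference.

From the compounds shown here alone, it remains open whether furan-2-yl would cost as much on compound 2, and how an amine or a carboxylic acid at this position would compare.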